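Swapping the hydroxyl position on a thiophene-bearing pyridine scaffold

The source may report more compounds than this note shows. Statements on the series, on what has been measured and on what is new or still open speak of the compounds shown alone.

Of the compounds shown here, three have been measured in an assay on isolated protein for inhibition of DNA topoisomerase 1 (Homo sapiens), with a stated time of 30 min, tested at 100 uM; on this read-out lower numbers stand for a weaker effect and higher numbers for a stronger effect at the one concentration tested. Compound 1 `Oc1ccc(-c2cc(-c3cccs3)cc(-c3cccc(O)c3)n2)cc1` gives 85.7%, and compound 2 `Oc1ccc(-c2cc(-c3cccs3)cc(-c3ccc(O)cc3)n2)cc1` gives 86.3%. Compound 3 `Oc1cccc(-c2cc(-c3ccsc3)cc(-c3cccc(O)c3)n2)c1` gives 59.2%, the lowest of the three numbers, and its gap to both compound 1 and compound 2 lies beyond the scatter. The difference between the core of compound 1 and the core of compound 3 is not broken down here.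

Compound 4 `Oc1ccc(-c2cc(-c3ccsc3)cc(-c3cccc(O)c3)n2)cc1` has not yet been measured in this assay. It differs from compound 3 by 4-hydroxyphenyl in place of 3-hydroxyphenyl on an aromatic carbon. The same kind of change is made from compound 1 to compound 2, described as 4-hydroxyphenyl in place of 3-hydroxyphenyl on an aromatic carbon, and there it gave a number 0.6 percentage points higher from compound 1 to compound 2 (within the scatter). The two changes are not the same, however: in compound 3 the place is meta to a 3-hydroxyphenyl group and meta to a thiophen-3-yl group, whereas in compound 1 it is meta to a 4-hydroxyphenyl group and meta to a thiophen-2-yl group.

Because the step from compound 1 to compound 2 was a number 0.6 percentage points higher from compound 1 to compound 2 (within the scatter), the step from compound 3 to compound 4 is expected to be small as well, estimated at a number 0.8 percentage points higher from compound 3 to compound 4 (within the scatter). Within the data shown here, compound 4 is therefore expected to give about 60% in this assay, estimated to lie between 45% and 75%, resting on the single comparable step and on compound 3 as the starting point.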

Compound 4, a percentage reported as inhibition, at one concentration (the size of the read-out at that concentration, not a potency): 17.1%
For compound 4 the middle estimate is 42.9 percentage points above the measured one; the whole stated range lies above it.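

In this assay, putting 4-hydroxyphenyl in place of 3-hydroxyphenyl on the core of compound 3 gives a number 42.1 percentage points lower from compound 3 to compound 4 (beyond the scatter), and thiophen-3-yl in place of thiophen-2-yl gives a number 68.6 percentage points lower from compound 1 to compound 4 (beyond the scatter), so compound 4 differs sharply from its two closest relatives despite small changes in structure. A hydroxyl shift that makes no visible difference on one core can therefore not be assumed to do the same on another, as the two matching steps show: the same change on two cores in this assay, a number 0.6 percentage points higher (within the scatter) from compound 1 to compound 2 and a number 42.1 percentage points lower (beyond the scatter) from compound 3 to compound 4, 42.7 percentage points apart, beyond the scatter of two such steps. This does not show why the steps differ or which difference between the cores matters, since the core of compound 1 carries 4-hydroxyphenyl and thiophen-2-yl where the core of compound 3 carries 3-hydroxyphenyl and thiophen-3-yl, and two pairs of compounds cannot separate those groups or establish a rule for the wider series.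

Every compound shown has two hydroxyphenyl groups and one thiophene, so it remains open how a methoxy group or an amine in place of a hydroxyl, or a plain phenyl in place of the thiophene, would behave. These readings tell only of a stronger or weaker effect at the one concentration tested, and leave open how the compounds compare at any other concentration.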